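Removing One Chloro Group from a Dichlorobenzyl Side Chain

A few compounds are considered here, and "the series" means these few. Any claim that something is new, unique, unknown or untested is made for them only; others in the source may bear on it.

Compound 2 `O=C1c2ccccc2N(Cc2ccc(Cl)c(Cl)c2)S(=O)(=O)N1Cc1ccccc1` is one of three compounds examined in a functional assay on HEL cells (Homo sapiens); on this read-out lower numbers stand for higher toxicity in this test and higher numbers for lower toxicity in this test. In this assay compound 2 gives 200000 nM. Compound 1 `O=C1c2ccccc2N(COCc2ccccc2)S(=O)(=O)N1COCc1ccccc1` carries different side chains on both ring nitrogens of the shared core; in this assay compound 1 gives 200000 nM. Going by the values given here, compound 3 `O=C1c2ccccc2N(Cc2ccccc2)S(=O)(=O)N1Cc1ccccc1Cl` differs from both in the placement of its single chloro group; in this assay compound 3 gives 200000 nM. At the digits shown, compound 2 stands level with compound 1 and with compound 3, and the three values lie within the scatter of each other, so no ordering among them can be drawn.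

Compound 4 `O=C1c2ccccc2N(Cc2ccc(Cl)cc2)S(=O)(=O)N1Cc1ccccc1` differs from compound 2 in one place: hydrogen in place of chloro on an aromatic carbon. The chloro group that leaves sits on an aromatic carbon of a six-membered aromatic ring of carbon only, ortho to a chloro group and meta to a large group; read one bond further out, the change is 3,4-dichlorobenzyl to 4-chlorobenzyl.

Among the compounds with values here, no step between measured compounds is available, so the effect of this change cannot be read from a matched pair. Since compounds 1, 2 and 3 all sit at the same value in this assay despite differing side chains, the step from compound 2 to compound 4 is expected to be none beyond the scatter, estimated as no change at the digits printed from compound 2 to compound 4 (within the scatter). Compound 4 is therefore expected to give 200000 nM, with a range from 100000 nM to 200000 nM.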

Compound 4, minimum cytotoxic concentration: > 5000 nM
Compound 4: no number, only a limit (the forecaster's own chance of this, stated with the estimate: 40%); the middle value lies beyond the limit too.
By their numbers in this assay, from the lowest: compounds 1, 2 and 3 (each within the scatter of the next).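

In this assay compound 4 gives > 5000 nM as a limit and not as a number. Going by these compounds alone, no step from compound 2 to compound 4 can be read, because the result for compound 4 is a limit: the limit of > 5000 nM in this assay, at which 1 of the 4 values shown sits. The compounds shown leave open whether hydrogen in place of chloro on this aromatic carbon changes the read-out at all.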